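A few compounds are considered here, and "the series" means these few. Any claim that something is new, unique, unknown or untested is made for them only; others in the source may bear on it.

Of the compounds shown here, three that share one core have been tested in an assay on Sf9 cells for inhibition of protein deacetylase HDAC6 (Homo sapiens), read by fluorescence, with a stated time of 40 min, tested at 100 nM; a higher number here means more inhibition at the concentration tested (going by the name of the read-out), a lower number less inhibition. Compound 1 `O=C(NO)c1ccc(NCc2nc(-c3ccco3)nn2-c2ccccc2)cc1` gives 59.9%. Compound 2 `O=C(NO)c1ccc(NCc2nc(-c3ccc(F)cc3)nn2-c2ccccc2)cc1` gives 70.9%, and compound 3 `O=C(NO)c1ccc(NCc2nc(-c3cc4ccccc4s3)nn2-c2ccccc2)cc1` gives 65.5%. Among these three numbers compound 3 stands second highest: its nearest neighbour is compound 2, whose number is higher by an amount within the scatter, and its furthest is compound 1, whose number is lower by an amount also within the scatter. Going by the values given here, the only measured step beyond the scatter is a number 11 percentage points higher from compound 1 to compound 2 (beyond the scatter), a modest rise when 4-fluorophenyl replaces furan-2-yl.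

Compound 4 `O=C(NO)c1ccc(NCc2nc(-c3ccc(C(F)(F)F)cc3)nn2-c2ccccc2)cc1` has not yet been measured. It differs from compound 3 in one place: 4-(trifluoromethyl)phenyl in place of 1-benzothiophen-2-yl on an aromatic carbon. The step that bears most directly on this change is a number 5.4 percentage points lower from compound 2 to compound 3 (within the scatter), which exchanged a 4-fluorophenyl for the 1-benzothiophen-2-yl and stayed within the scatter. Compound 4 carries a 4-(trifluoromethyl)phenyl, again a six-membered ring of carbon only, so moving back from 1-benzothiophen-2-yl to such a ring is expected to give a step of about a number 4.5 percentage points higher from compound 3 to compound 4 (within the scatter), not beyond the scatter. Compound 4 is therefore estimated at 70% in this assay, within a range from 58% to 82%.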

Compound 4, a percentage reported as inhibition, at one concentration (the size of the read-out at that concentration, not a potency): 41.6%
The estimate for compound 4 lay 28.4 percentage points above the measured number, and the stated range ends above it.
By their numbers in this assay, from the lowest: compound 4; then compounds 1, 3 and 2 (each within the scatter of the next, the first and the last beyond it).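

In this assay this position does not treat all rings carrying a six-membered aromatic ring of carbon only alike: trifluoromethyl in place of fluoro gives a number 29.3 percentage points lower from compound 2 to compound 4 (beyond the scatter), so the substituent on that ring matters and not just the ring itself. Replacing 1-benzothiophen-2-yl with 4-(trifluoromethyl)phenyl gives a number 23.9 percentage points lower from compound 3 to compound 4 (beyond the scatter), and replacing furan-2-yl with it gives a number 18.3 percentage points lower from compound 1 to compound 4 (beyond the scatter), so 4-(trifluoromethyl)phenyl is the one group shown that stands clearly apart from all three others, while those three lay much closer together. No measurement at hand accounts for this fall.

The compounds shown leave open whether the loss is particular to trifluoromethyl or would also appear with methyl, methoxy, chloro or a nitrile in its place on the phenyl ring. They also leave open how an amine or a carboxylic acid on that ring would read, and whether the same exchange of fluoro for trifluoromethyl would give a similar step on a core with a different group in place of the phenyl.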